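Efficacy notes: amine substituent change at the piperidine-bearing position

The source may report more compounds than this note shows. Statements on the series, on what has been measured and on what is new or still open speak of the compounds shown alone.

Of the compounds shown here, three have been measured in a functional assay on isolated protein for agonist activity at Glucose-dependent insulinotropic receptor (Homo sapiens), read by HTRF and cAMP accumulation; on this read-out higher numbers stand for larger maximal responses and lower numbers for smaller maximal responses. Compound 1 `CC(C)(C)OC(=O)N1CCC(O[C@H]2CC[C@H](Oc3cnc(S(C)(=O)=O)cn3)CC2)CC1` gives 110%. Compound 2 `CC(C)(C)OC(=O)N1CCC(O[C@H]2CC[C@H](Oc3ccc(S(C)(=O)=O)nn3)CC2)CC1` gives 97%, and compound 3 `C[C@@H](CF)OC(=O)N1CCC(O[C@H]2CC[C@H](Oc3cnc(S(C)(=O)=O)cn3)CC2)CC1` gives 105%. Compound 3 lies within the scatter of both compound 1 and compound 2, so the three maximal responses are not separable on these numbers.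

Compound 4 `CS(=O)(=O)c1cnc(O[C@H]2CC[C@H](OC3CCN(CC4(C(F)(F)F)CCC4)CC3)CC2)cn1` carries the change (a group of 9 heavy atoms (6 carbon, 3 fluorine; one four-membered non-aromatic ring of carbon only) in place of a group of 7 heavy atoms (4 carbon, 2 oxygen, 1 fluorine; no ring), on an amine nitrogen in a ring). For the measured compounds named here, no measured step touches this position. The nearest comparison is a number 5 percentage points lower from compound 1 to compound 3 (within the scatter), a change on an oxygen next to a carbonyl group that left the maximal response unchanged within scatter. The step of a number 13 percentage points lower from compound 1 to compound 2 (beyond the scatter) concerns the aromatic ring on the other side of the shared core and does not bear on the present change. All three measured compounds reach a full response, so the expectation for compound 4 is no change beyond the scatter, a number 5 percentage points lower from compound 3 to compound 4 (within the scatter), with a wider range allowed for an untested position. Compound 4 is estimated at 100%, between 80% and 115%.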

Compound 4, largest response reached (Emax), in percent of the reference or control that the assay uses: 96%
For compound 4 the middle estimate is 4 percentage points above the measured one; measured number inside the range.
By their numbers in this assay, from the lowest: compounds 4, 2, 3 and 1 (each within the scatter of the next, the first and the last beyond it).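

At the amine nitrogen in a ring, (1-(trifluoromethyl)cyclobutyl)methyl, with 0 hydrogen-bond acceptors, replaces groups that carry a carbonyl, and in this assay the outcome depends on the comparison: a number 9 percentage points lower from compound 3 to compound 4 (within the scatter), but a number 14 percentage points lower from compound 1 to compound 4 (beyond the scatter) against tert-butoxycarbonyl. A carbonyl-bearing group on this nitrogen is therefore not required for a high maximal response, as compound 4 still gives 96%, although the step from tert-butoxycarbonyl is a real, modest one. No data accompany these numbers that would account for either step.

Still open, from the compounds shown here alone, is how much of the response depends on the trifluoromethyl, which a plain cyclobutylmethyl or benzyl group on the same nitrogen would help to show. Also open, going by these compounds, is whether the step holds with 6-(methylsulfonyl)pyridazin-3-yl on the other side of the shared core.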